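The source may hold more compounds than are shown below. What is called first, only, known or untested is meant among the compounds shown, and "the series" means these compounds.

Compound 1, `CC(C)n1ncc2c(C(=O)NC3CCCC3)cccc21`: in a functional assay on MGC-803 cells (Homo sapiens) for inhibition, read by MTT assay, with a stated time of 72 h (on this read-out higher numbers stand for weaker inhibition and lower numbers for stronger inhibition), compound 1 gives > 40000 nM, which is a limit of the assay rather than a number.
Compound 2, `CC(C)n1ncc2c(C(=O)NCc3cn(-c4ccccc4)nn3)cccc21`: in this assay compound 2 gives > 40000 nM, again a limit of the assay rather than a number.

So compound 2 stands at the limit, not at a measured number; indeed (the limit of > 40000 nM in this assay, at which 2 of the 2 values shown sit), so both measured compounds sit at the same limit and neither shows any inhibition the assay can quantify.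

The next compound, compound 3 `CC(C)n1ncc2c(C(=O)NCc3cn(-c4ccc(F)cc4)nn3)cccc21`, is made from compound 2 by the change (fluoro in place of hydrogen on an aromatic carbon), fluoro in place of hydrogen on an aromatic carbon. Going by the values given here, no step between two measured compounds exists here to guide the expectation. With both measured values at the limit in this assay, the expected step from compound 2 to compound 3 is none beyond the scatter, and the likely outcome is that compound 3 also reports only a limit. For compound 3 the estimate is 60000 nM, with a range from 20000 nM to 200000 nM, meaning an expected step that the limit leaves unreadable from compound 2 to compound 3.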

Compound 3, half-maximal inhibitory concentration: > 40000 nM
Compound 3: a limit, no number; the forecaster's own chance of this, stated with the estimate: 85%; the middle value lies beyond the limit too.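

Compound 2 and compound 3 both give only a limit, not a number, so no step can be read between them in this assay: the limit of > 40000 nM in this assay, at which 3 of the 3 values shown sit. The compounds shown leave open whether the change from phenyl to 4-fluorophenyl makes any difference to inhibition in this assay.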